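The source may hold more compounds than are shown below. What is called first, only, known or untested is meant among the compounds shown, and "the series" means these compounds.

Compound 2, with the structure `COc1cc(-c2nnc(SCC(=O)Nc3ccc(C)cc3)n2N)cc(OC)c1OC`, carries an amide whose nitrogen bears a 4-methylphenyl group. In a functional assay on HepG2 cells (Homo sapiens) for antiproliferative activity, read by MTT assay, with a stated time of 48 h (on this read-out higher numbers stand for weaker inhibition and lower numbers for stronger inhibition), compound 2 gives > 100000 nM, which is a limit of the assay rather than a number. Compound 1, with the structure `COc1cc(-c2nnc(SCC(=O)c3ccccc3F)n2N)cc(OC)c1OC`, instead has a 2-fluorophenyl group on a carbonyl carbon and gives 22600 nM in this assay. For the measured compounds named here, the only measured step, an at least 4.4-fold higher number from compound 1 to compound 2 (0.64 log units; beyond the scatter), shows that swapping the ketone for this anilide pushes the value past the upper end of the assay, and the limit of > 100000 nM in this assay, at which 1 of the 2 values shown sits, marks how much of the small set already sits there. Compound 3, with the structure `COc1cc(-c2nnc(SCC(=O)NCc3ccc(Cl)cc3)n2N)cc(OC)c1OC`, differs from compound 2 by 4-chlorobenzyl in place of 4-methylphenyl on an amide-type nitrogen. Going by the values given here, no measured step bears directly on this change, and the compounds in hand give no way to separate the benzyl from the aryl amide. Compound 3 is therefore expected to remain near the limit, with a number no higher from compound 2 to compound 3 (the limit leaves the size open) amounting to no step beyond the scatter. Compound 3 is estimated at 100000 nM, with a range from 30000 nM to 300000 nM.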

Compound 3, half-maximal inhibitory concentration: > 100000 nM
Compound 3: only a limit was reported (the forecaster's own chance of this, stated with the estimate: 65%); the middle value sits exactly at the limit.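

In this assay compound 3 gives > 100000 nM, which is again a limit of the assay and not a number. With (4-chlorobenzyl)amino in place of 2-fluorophenyl on the carbonyl carbon there is an at least 4.4-fold higher number from compound 1 to compound 3 (0.64 log units; beyond the scatter), so the shift away from the ketone of the first compound is now seen with two different amides, and neither amide goes against it. What is new is that adding a carbon to the link and replacing the methyl with a chlorine on the ring still leaves the amide at the limit, although the step between the two amides cannot be read, as neither has a real number, and the small set now looks like this: the limit of > 100000 nM in this assay, at which 2 of the 3 values shown sit.

Going by these compounds, it remains open whether any group on the amide-type nitrogen could bring the value back within the range of the assay, for example a simple methyl, a morpholine ring or a chain ending in a carboxylic acid. On these data alone, with only one ketone in view, it also remains open how much of its measurable value belongs to the ketone itself and how much to the 2-fluorophenyl group, which a plain phenyl ketone would help to separate.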